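Replacing Fluorine with Bromine on the Attached Ring

A few compounds are considered here, and "the series" means these few. Any claim that something is new, unique, unknown or untested is made for them only; others in the source may bear on it.

Two compounds share a core and differ only in the ring attached to it. Compound 1 `Nc1scc(-c2ccccc2F)c1C(=O)c1ccccc1` carries a 2-fluorophenyl; in a functional assay on CHO cells for agonist activity at adenosine receptor A1 (Homo sapiens), read by fluorescence and ERK phosphorylation, with stated times of 30 min and 1.5 h, tested at 10 uM (on this read-out higher numbers stand for a stronger effect at the one concentration tested and lower numbers for a weaker effect), compound 1 gives 68%. Compound 2 `Nc1scc(-c2ccc(F)cc2)c1C(=O)c1ccccc1` carries a 4-fluorophenyl, and in this assay compound 2 gives 60%. The step of a number 8 percentage points lower from compound 1 to compound 2 (within the scatter) shows that these two values lie within the scatter of each other, so neither compound can be called stronger on the numbers shown. Compound 3 `Nc1scc(-c2ccc(Br)cc2)c1C(=O)c1ccccc1` has not yet been measured; it differs from compound 1 as follows: 4-bromophenyl in place of 2-fluorophenyl on an aromatic carbon. Among the measured compounds shown here, the one measured step that bears on it, a number 8 percentage points lower from compound 1 to compound 2 (within the scatter), replaced 2-fluorophenyl with 4-fluorophenyl without an effect beyond the scatter, and no measured pair speaks to the change from fluorine to bromine. The expected step is therefore a number 8 percentage points lower from compound 1 to compound 3 (within the scatter), none beyond the scatter. For compound 3 the estimated value in this assay is 60%, with a range from 40% to 80%.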

Compound 3, a percentage reported as activity, at one concentration (the size of the read-out at that concentration, not a potency): 49%
Compound 3: middle estimate off by 11 percentage points, on the high side; low and high end bracket the measured number.
By their numbers in this assay, from the lowest: compound 3; then compounds 2 and 1 (each within the scatter of the next).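

In this assay, bromo in place of fluoro on the attached ring gives a number 11 percentage points lower from compound 2 to compound 3 (beyond the scatter) and so shows that this position responds to a change of halogen, which the earlier pair could not show. The full change, 4-bromophenyl in place of 2-fluorophenyl, gives a number 19 percentage points lower from compound 1 to compound 3 (beyond the scatter) and also lies beyond the scatter, whereas the earlier step between the two fluorophenyl compounds did not. No measurement at hand accounts for the lower numbers with bromine.

On these data alone, it remains open whether a 2-bromophenyl would read like the 4-bromophenyl, and how a chloro, methoxy or amino group would read on the same ring. Each number also comes from one concentration, so these results leave the potency of all three compounds open.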